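The source may hold more compounds than are shown below. What is called first, only, known or untested is meant among the compounds shown, and "the series" means these compounds.

Measured compounds:
compound 1, `N#CC1=C(N)Oc2c(N)cc3nc4ccccc4nc3c2C12C(=O)N(Cc1cnnn1-c1cccc(C(F)(F)F)c1)c1ccccc12`, gives 5400 nM in a functional assay on A549 cells (Homo sapiens) for antiproliferative activity, read by MTT assay, with a stated time of 48 h; on this read-out lower numbers stand for stronger inhibition and higher numbers for weaker inhibition.
compound 2, `COc1ccccc1-n1nncc1CN1C(=O)C2(C(C#N)=C(N)Oc3c(N)cc4nc5ccccc5nc4c32)c2ccccc21`, gives 37500 nM in this assay.
compound 3, `CCOc1ccccc1-n1nncc1CN1C(=O)C2(C(C#N)=C(N)Oc3c(N)cc4nc5ccccc5nc4c32)c2ccccc21`, gives only a limit of the assay, > 50000 nM in this assay.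

Compound 3 thus stands at the weak end of the three, resting on (the limit of > 50000 nM in this assay, at which 1 of the 3 values shown sits); its result is a limit rather than a number. Within the data shown here, the steps that bear on the aryl group on the aromatic nitrogen are a 6.9-fold higher number from compound 1 to compound 2 (0.84 log units; beyond the scatter) and an at least 9.2-fold higher number from compound 1 to compound 3 (0.96 log units; beyond the scatter), both running upward from the 3-(trifluoromethyl)phenyl compound. Between the two alkoxy compounds, an at least 1.3-fold higher number from compound 2 to compound 3 (0.12 log units; that floor lies within the scatter).

Compound 4, `Cc1cc(C)cc(-n2nncc2CN2C(=O)C3(C(C#N)=C(N)Oc4c(N)cc5nc6ccccc6nc5c43)c3ccccc32)c1`, differs from compound 3 by 3,5-dimethylphenyl in place of 2-ethoxyphenyl on an aromatic nitrogen. Among the measured compounds shown here, no measured step exchanges an alkoxyphenyl for a dimethylphenyl, so the direction is inferred only from the fact that both alkoxyphenyl compounds, compound 2 and compound 3, sit higher than compound 1, whose aryl group likewise carries no alkoxy group. A move back toward compound 1 is therefore expected, but from a limit the size of that move cannot be fixed; a modest downward step an at least 2.7-fold lower number from compound 3 to compound 4 (0.44 log units; beyond the scatter) is the estimate, with a real chance that the assay again returns only a limit.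

Compound 4 is expected to give about 18000 nM in this assay, within 4000 nM to 50000 nM.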

Compound 4, half-maximal inhibitory concentration: 31200 nM
The estimate for compound 4 lay 1.7-fold (0.24 log units) below the measured number, within the range that was stated.
By their numbers in this assay, from the lowest: compound 1; then compounds 4 and 2 (each within the scatter of the next). At a limit, above all of these: compound 3.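

In this assay, compound 4 shows that an aryl group with no alkoxy group does not by itself restore the level of the 3-(trifluoromethyl)phenyl compound: a 5.8-fold higher number from compound 1 to compound 4 (0.76 log units; beyond the scatter). The exchange of 2-methoxyphenyl for 3,5-dimethylphenyl, with a 1.2-fold lower number from compound 2 to compound 4 (0.08 log units; within the scatter), makes no readable difference at this position, so alkoxy against two methyl groups does not separate these two compounds. Compound 3 remains a limit, so an at least 1.6-fold lower number from compound 3 to compound 4 (0.20 log units; that floor lies within the scatter) sets only a floor for this exchange and does not fix its size: the limit of > 50000 nM in this assay, at which 1 of the 4 values shown sits.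

Among the aryl groups shown, only the 3-(trifluoromethyl)phenyl group stands apart, and it rests on compound 1 alone, so it stays open whether the trifluoromethyl group itself or its place on the ring carries the gap. Also open, from the compounds shown here alone, is how this position responds to other groups, such as a chlorophenyl, a pyridine ring or a phenyl ring bearing an amine or a carboxylic acid, and whether any of them improves on compound 1, at 5400 nM.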